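The source may hold more compounds than are shown below. What is called first, only, known or untested is meant among the compounds shown, and "the series" means these compounds.

Measured compounds:
Compound 1, `CC1CCC(=NNc2ccc(Cl)c(Cl)c2)c2ncc(C(=O)O)c(=O)n21` — in a functional assay on the whole organism with Rattus norvegicus as the target (on this read-out higher numbers stand for an effect only at larger amounts of compound and lower numbers for an effect already at smaller amounts), compound 1 gives > 100 umol/kg, a limit of the assay rather than a number.
Compound 2, `CC1CCC(=NNc2cc(Cl)cc(Cl)c2)c2ncc(C(=O)O)c(=O)n21` — in this assay compound 2 gives > 100 umol/kg, which is likewise a limit and not a number.

Compound 2 thus stands only at a limit in this assay; both values shown sit at that same limit, (the limit of > 100 umol/kg in this assay, at which 2 of the 2 values shown sit). Among the measured compounds shown here, the single measured step, a step that the two limits leave unreadable from compound 1 to compound 2, is one the two limits leave unreadable, so its size is unknown. Compound 3, `Cc1cc(NN=C2CCC(C)n3c2ncc(C(=O)O)c3=O)ccc1Br`, differs from compound 2 by 4-bromo-3-methylphenyl in place of 3,5-dichlorophenyl on an amine nitrogen. That earlier step, a step that the two limits leave unreadable from compound 1 to compound 2, concerns a change at the same amine nitrogen, but it gives no readable size, and with compound 2 sitting at the limit of > 100 umol/kg in this assay, at which 2 of the 2 values shown sit, there is no basis to expect a step beyond the scatter; the estimated step that the limit leaves unreadable from compound 2 to compound 3 is accordingly small. Compound 3 is therefore expected at 150 umol/kg, with a range from 40 umol/kg to 600 umol/kg, and most likely reported again only as a limit.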

Compound 3, dose for 50% inhibition: > 100 umol/kg
Compound 3: a limit, no number; the forecaster's own chance of this, stated with the estimate: 75%; the middle value does not contradict the limit.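

Compound 3 also gives only a limit in this assay, so no step among compound 1, compound 2 and compound 3 can be read: the limit of > 100 umol/kg in this assay, at which 3 of the 3 values shown sit.

The compounds shown leave open what dose any of them would need for an effect, and whether the three groups on the amine nitrogen differ at all.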